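The source may hold more compounds than are shown below. What is called first, only, known or untested is meant among the compounds shown, and "the series" means these compounds.

The series shares the core of compound 1 `CCC(C)(O)CC(=O)O[C@H](CC=C(C)C)C1=CC(=O)c2c(O)ccc(O)c2C1=O`, an ester on the side chain bearing a hydroxylated alkyl arm. In a functional assay on HeLa cells (Homo sapiens) for cytotoxicity, read by MTT assay (on this read-out higher numbers stand for weaker inhibition and lower numbers for stronger inhibition), compound 1 gives 25200 nM. Compound 2 `CC(C)=CC[C@@H](OC(=O)CC(C)(O)c1ccccc1)C1=CC(=O)c2c(O)ccc(O)c2C1=O` gives 85700 nM in this assay, and compound 3 `CCCC(C)(O)CC(=O)O[C@H](CC=C(C)C)C1=CC(=O)c2c(O)ccc(O)c2C1=O` gives 72000 nM. Compound 2 thus stands at the high end of the three numbers: the nearest is compound 3, with a 1.2-fold lower number from compound 2 to compound 3 (0.08 log units; within the scatter), and the furthest is compound 1, with a 3.4-fold higher number from compound 1 to compound 2 (0.53 log units; beyond the scatter). The third measured step, a 2.9-fold higher number from compound 1 to compound 3 (0.46 log units; beyond the scatter), adds a methyl at a different place.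

Compound 4 `CC(C)=CC[C@@H](OC(=O)CC(C)(O)C(C)C)C1=CC(=O)c2c(O)ccc(O)c2C1=O` differs from compound 2 by isopropyl in place of phenyl on a saturated chain carbon bound to an oxygen on a saturated carbon and two saturated chain carbons. Among the compounds with values here, two steps bear on this change. Replacing phenyl by propyl at the same place, a 1.2-fold lower number from compound 2 to compound 3 (0.08 log units; within the scatter), stayed within the scatter; replacing ethyl by phenyl there, a 3.4-fold higher number from compound 1 to compound 2 (0.53 log units; beyond the scatter), gave a modestly higher number. A branched alkyl in place of phenyl is therefore expected to give at most a modest lower number, and possibly none beyond the scatter. Compound 4 is expected at 50000 nM, with a range from 20000 nM to 120000 nM. The expected step is a 1.7-fold lower number from compound 2 to compound 4 (0.23 log units; within the scatter).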

Compound 4, half-maximal inhibitory concentration: 27700 nM
Estimate against measurement, compound 4: 1.8-fold (0.26 log units) above; low and high end bracket the measured number.
By their numbers in this assay, from the lowest: compounds 1 and 4 (each within the scatter of the next); then compounds 3 and 2 (each within the scatter of the next).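

In this assay isopropyl at this position parts from both phenyl (a 3.1-fold lower number from compound 2 to compound 4 (0.49 log units; beyond the scatter)) and the unbranched propyl (a 2.6-fold lower number from compound 3 to compound 4 (0.41 log units; beyond the scatter)), so the earlier closeness of phenyl and propyl does not extend to every alkyl group placed here. Isopropyl stays level with ethyl (a 1.1-fold higher number from compound 1 to compound 4 (0.04 log units; within the scatter)), which puts ethyl and isopropyl together at the low end, while propyl goes against any reading in which alkyl groups here behave alike. Nothing available explains why propyl and isopropyl part at this position.

On these data alone, whether a longer chain such as butyl follows propyl, or a more branched group such as tert-butyl follows isopropyl, remains open. Also open, as far as these compounds go, is whether a saturated ring such as cyclohexyl, or an amine on this arm, would fall with phenyl or with isopropyl.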